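The source may report more compounds than this note shows. Statements on the series, on what has been measured and on what is new or still open speak of the compounds shown alone.

Among the compounds with values here, compound 2, `CC1CCN(c2c(S(=O)(=O)c3ccc(Cl)c(Cl)c3)cnc3ccc(F)cc23)CC1`, is one of two compounds measured in an assay on isolated protein for displacement of a labelled ligand from metabotropic glutamate receptor 5 (Homo sapiens), with a stated time of 60 min, tested at 1 uM (on this read-out lower numbers stand for less inhibition and higher numbers for more inhibition at the one concentration tested (going by the name of the read-out)), the other being compound 1, `CC1CCN(c2c(S(=O)(=O)c3cccc(Cl)c3)cnc3ccc(Cl)cc23)CC1`. In this assay compound 2 gives 91%, and compound 1 gives 92%; the two numbers sit within the usual scatter of each other, so neither can be set above the other. Compound 3, `CC1CCN(c2c(S(=O)(=O)c3cccc(Cl)c3)cnc3ccc(F)cc23)CC1`, has not yet been measured. It differs from compound 2 by hydrogen in place of chloro on an aromatic carbon. Within the data shown here, no step between two measured compounds shows what this change alone does, so no measured step can be cited. Since both compound 1 and compound 2 give high inhibition, compound 3 is expected to stay near them, with any step from compound 2 to compound 3 of a number 3 percentage points lower from compound 2 to compound 3 (within the scatter) in this assay expected to remain within the scatter. Compound 3 is estimated at 88%, in a range from 72% to 96%.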

Compound 3, a percentage reported as inhibition, at one concentration (the size of the read-out at that concentration, not a potency): 92%
For compound 3 the middle estimate is 4 percentage points below the measured one; low and high end bracket the measured number.
By their numbers in this assay, from the lowest: compounds 2, 1 and 3 (each within the scatter of the next).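

In this assay, going from the 3,4-dichlorophenyl to the 3-chlorophenyl gives a number 1 percentage points higher from compound 2 to compound 3 (within the scatter), so on this aromatic carbon the chloro can give way to hydrogen without a change that can be read. Fluoro in place of chloro on an aromatic carbon of the shared core gives no change at the digits printed from compound 1 to compound 3 (within the scatter), which likewise leaves the read-out where it was. Nothing available explains why either swap leaves the inhibition in place.

At a single concentration, all three compounds give similarly high numbers, so this read-out cannot show whether either change makes a smaller difference in potency. Still open, from the compounds shown here alone, is whether an amine or a carboxylic acid in place of that chloro would keep the inhibition, and whether the remaining chloro on the phenyl ring is needed at all.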